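Swapping the benzyl substituent in a hydroxamic acid series

The source may report more compounds than this note shows. Statements on the series, on what has been measured and on what is new or still open speak of the compounds shown alone.

Four compounds share one core: a hydroxamic acid carrying a methyl group, joined through a sulfonamide nitrogen to a methoxyphenyl sulfonyl group, with a variable group on a saturated chain carbon bound to that nitrogen. Compound 1 `COc1ccc(S(=O)(=O)N(CCn2cccc2)[C@H](C)C(=O)NO)cc1` carries a (1H-pyrrol-1-yl)methyl group; in an assay on isolated protein for inhibition of bone morphogenetic protein 1 (Homo sapiens) (a higher number here means a weaker inhibitor, a lower number a stronger inhibitor), compound 1 gives 170 nM. Compound 2 `COc1ccc(S(=O)(=O)N(Cc2ccc(SC)cc2)[C@H](C)C(=O)NO)cc1` carries a 4-(methylsulfanyl)phenyl group and gives 80 nM in this assay. Compound 3 `COc1ccc(S(=O)(=O)N(Cc2cc(F)cc(F)c2)[C@H](C)C(=O)NO)cc1` carries a 3,5-difluorophenyl group and gives 140 nM in this assay. Compound 3 sits between the other two, with both gaps inside the usual scatter: a 1.2-fold lower number from compound 1 to compound 3 (0.08 log units; within the scatter) and a 1.8-fold higher number from compound 2 to compound 3 (0.24 log units; within the scatter). Among the measured compounds shown here, the only step beyond the scatter is a 2.1-fold lower number from compound 1 to compound 2 (0.33 log units; beyond the scatter), which is modest.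

Compound 4 `COc1ccc(S(=O)(=O)N(Cc2ccc(Br)cc2)[C@H](C)C(=O)NO)cc1` is not yet measured in this assay. It differs from compound 3 in one place: 4-bromophenyl in place of 3,5-difluorophenyl on a saturated chain carbon bound to a sulfonamide nitrogen. The measured steps suggest that changing this group moves the number little. The expected value for compound 4 is 110 nM, within a range from 55 nM to 250 nM. This estimate corresponds to an expected step of a 1.3-fold lower number from compound 3 to compound 4 (0.10 log units; within the scatter), which stays within the scatter.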

Compound 4, half-maximal inhibitory concentration: 37 nM
Compound 4: middle estimate off by 3.0-fold (0.47 log units), on the high side; measured number outside the range, below it.
By their numbers in this assay, from the lowest: compound 4; then compounds 2, 3 and 1 (each within the scatter of the next, the first and the last beyond it).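

In this assay, among the compounds shown here, this position proves more responsive than the earlier compounds showed: the change brings a 3.8-fold lower number from compound 3 to compound 4 (0.58 log units; beyond the scatter), the largest step yet between 3,5-difluorophenyl and any other group compared here. Bromo in place of methylsulfanyl on an aromatic carbon also gives a 2.2-fold lower number from compound 2 to compound 4 (0.33 log units; beyond the scatter), and replacing (1H-pyrrol-1-yl)methyl with 4-bromophenyl gives a 4.6-fold lower number from compound 1 to compound 4 (0.66 log units; beyond the scatter), so compound 4 is the strongest inhibitor of the four, with every step to it beyond the scatter. Nothing available here accounts for why the 4-bromophenyl group gives the lowest number.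

As far as these compounds go, whether chloro, iodo or trifluoromethyl in place of bromo on an aromatic carbon would keep the number this low remains open. So does the outcome for an amine or a carboxylic acid on that aromatic carbon.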